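Ethoxy in place of 4-aminophenyl: expectation for compound 3

The source may hold more compounds than are shown below. What is called first, only, known or untested is meant among the compounds shown, and "the series" means these compounds.

Compound 1 `Cc1cc(S(=O)(=O)N2C(=O)N[C@@H](c3ccccc3)C2C)ccc1NC(=O)c1ccc(N)cc1` in a functional assay on A549 cells (Homo sapiens) for cytotoxicity, read by MTT assay (on this read-out lower numbers stand for stronger inhibition and higher numbers for weaker inhibition), gives only a limit, > 10000 nM. Compound 2 `CC1[C@H](c2ccccc2)NC(=O)N1S(=O)(=O)c1ccc(NC(=O)c2ccc(N)cc2)c(Cl)c1` likewise gives only a limit in this assay, > 10000 nM. The step from compound 1 to compound 2, a step that the two limits leave unreadable from compound 1 to compound 2, chloro in place of methyl on an aromatic carbon, cannot be sized because both values sit at the limit of > 10000 nM in this assay, at which 2 of the 2 values shown sit. Compound 3 `CCOC(=O)Nc1ccc(S(=O)(=O)N2C(=O)N[C@@H](c3ccccc3)C2C)cc1C` differs from compound 1 by ethoxy in place of 4-aminophenyl on a carbonyl carbon. Within the data shown here, no measured step touches the carbonyl carbon; the only guide is that every value shown is a limit. The step from compound 1 to compound 3 is therefore expected as a step that the limit leaves unreadable from compound 1 to compound 3, most likely again ending at a limit. Compound 3 is estimated at 20000 nM, within 5000 nM to 80000 nM.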

Compound 3, half-maximal inhibitory concentration: 5000 nM
For compound 3 the middle estimate is 4.0-fold (0.60 log units) above the measured one; the measured number falls inside the stated range.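

Among these compounds, on the carbonyl carbon, ethoxy in place of 4-aminophenyl gives the first number in this assay that is not a limit, with an at least 2.0-fold lower number from compound 1 to compound 3 (0.30 log units; that floor lies within the scatter). The full size of this step cannot be read, and its floor does not clear the scatter. Compound 3 is the only compound of the three read as a number; the others stand at one limit: the limit of > 10000 nM in this assay, at which 2 of the 3 values shown sit.

Going by these compounds, whether ethoxy itself matters, or only the loss of 4-aminophenyl, stays open. So does the effect of a longer chain such as butoxy, or of an amine such as dimethylamino, on the same carbonyl carbon.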